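From 4-methoxyphenyl to 2,5-dimethoxyphenyl in compound 4

A few compounds are considered here, and "the series" means these few. Any claim that something is new, unique, unknown or untested is made for them only; others in the source may bear on it.

Values measured in a functional assay on L1210 cells (Mus musculus) for antiproliferative activity, read by MTT assay, with a stated time of 72 h; a higher number here means a weaker inhibitor, a lower number a stronger inhibitor:
Compound 1 `COc1cc(C2=NN(C(C)=O)C(c3cccc([N+](=O)[O-])c3)O2)cc(OC)c1OC` gives 39000 nM
Compound 2 `COc1ccc(C2OC(c3cc(OC)c(OC)c(OC)c3)=NN2C(C)=O)cc1` gives 57000 nM
Compound 3 `COc1ccc(C2OC(c3cc(OC)c(OC)c(OC)c3)=NN2C(C)=O)cc1OC(C)=O` gives 3900 nM

Compound 2 shares the high end of these numbers with compound 1 (a 1.5-fold higher number from compound 1 to compound 2 (0.16 log units; within the scatter)). Compound 3 stands well apart (a 15-fold lower number from compound 2 to compound 3 (1.16 log units; beyond the scatter)). Compound 4 `COc1ccc(OC)c(C2OC(c3cc(OC)c(OC)c(OC)c3)=NN2C(C)=O)c1` alters compound 2 at one place (2,5-dimethoxyphenyl in place of 4-methoxyphenyl on a saturated ring carbon), with 2,5-dimethoxyphenyl in place of 4-methoxyphenyl on a saturated ring carbon. The earlier exchange on that carbon stayed within the scatter (a 1.5-fold higher number from compound 1 to compound 2 (0.16 log units; within the scatter)). The large step came with an acetoxy group on an aromatic carbon (a 15-fold lower number from compound 2 to compound 3 (1.16 log units; beyond the scatter)), and compound 4 has none. In this assay a small move toward lower numbers is therefore expected, not one beyond the scatter. The estimated step is small (a 1.6-fold lower number from compound 2 to compound 4 (0.21 log units; within the scatter)). For compound 4 the estimated value is 35000 nM (range 12000 nM to 90000 nM).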

Compound 4, half-maximal inhibitory concentration: 55000 nM
For compound 4 the middle estimate is 1.6-fold (0.20 log units) below the measured one; the range from low to high includes it.
By their numbers in this assay, from the lowest: compound 3; then compounds 1, 4 and 2 (each within the scatter of the next).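

Exchanging 4-methoxyphenyl for 2,5-dimethoxyphenyl on the saturated ring carbon left the number in this assay within the scatter (a 1.0-fold lower number from compound 2 to compound 4 (0.02 log units; within the scatter)), and the exchange for 3-nitrophenyl at that carbon did too (a 1.4-fold higher number from compound 1 to compound 4 (0.15 log units; within the scatter)). Among these compounds, an added methoxy group thus gave no step of its own here, and the only large step at this position remains the one with the acetoxy group of compound 3. Nothing measured here gives a reason for this result. Going by these compounds, whether a hydroxy group or an amine on that phenyl ring would produce a large step remains open. So does the effect of a longer chain in place of the acetyl group.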